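The compounds below may be only part of what the source reports. "The series", "measured", "known", "first", "only" and "open" are said of these compounds alone.

Measured in a functional assay on A549 cells (Homo sapiens) for antiproliferative activity, read by MTT assay, with a stated time of 48 h; a higher number here means a weaker inhibitor, a lower number a stronger inhibitor:
- compound 1 `CCOc1cc(-c2ccc3c(ccn3C)c2)cn2c(-c3cc(OC)c(OC)c(OC)c3)nnc12`: 334 nM
- compound 2 `COc1cc(-c2nnc3c(OC(C)C)cc(-c4ccc5c(ccn5C)c4)cn23)cc(OC)c1OC`: 322 nM
- compound 3 `COc1cc(-c2nnc3c(OC4COC4)cc(-c4ccc5c(ccn5C)c4)cn23)cc(OC)c1OC`: 516 nM

Not yet measured: compound 4 `COc1cc(-c2nnc3c(OCC(F)(F)F)cc(-c4ccc5c(ccn5C)c4)cn23)cc(OC)c1OC`.

The three measured compounds share one core and differ only in the group on the oxygen on an aromatic ring. Compound 3, at 516 nM, lies within the scatter of both other compounds, so this assay does not separate it from either.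

The next change is 2,2,2-trifluoroethyl in place of oxetan-3-yl on an oxygen on an aromatic ring, which puts 2,2,2-trifluoroethyl in place of oxetan-3-yl. This exact change has not been measured. Among the compounds with values here, the steps that bear on it are the three exchanges already made at this oxygen: a 1.0-fold lower number from compound 1 to compound 2 (0.02 log units; within the scatter), a 1.5-fold higher number from compound 1 to compound 3 (0.19 log units; within the scatter) and a 1.6-fold higher number from compound 2 to compound 3 (0.20 log units; within the scatter). All three stay within the scatter. Within the data shown here, the closest measured group by name is the ethyl of compound 1, at 334 nM, but no measured compound carries fluorine, so the effect of the trifluoroethyl group is untested in this small set.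

No step beyond the scatter is therefore expected, in either direction. The estimate corresponds to a 1.3-fold lower number from compound 3 to compound 4 (0.11 log units; within the scatter), which is expected to remain within the scatter. For compound 4 the estimated value is 400 nM, with an expected range from 190 nM to 850 nM.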

Compound 4, half-maximal inhibitory concentration: 614 nM
Estimate against measurement, compound 4: 1.5-fold (0.19 log units) below, within the range that was stated.
By their numbers in this assay, from the lowest: compounds 2, 1, 3 and 4 (each within the scatter of the next).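

In this assay, within the data shown here, the only fluorine-bearing group on this oxygen stays within the scatter of all three earlier groups: a 1.2-fold higher number from compound 3 to compound 4 (0.08 log units; within the scatter), a 1.9-fold higher number from compound 2 to compound 4 (0.28 log units; within the scatter) and a 1.8-fold higher number from compound 1 to compound 4 (0.26 log units; within the scatter). The last of these steps is the direct test of fluorine at this position, as it places trifluoromethyl in place of methyl on a saturated chain carbon bound to an oxygen on an aromatic ring, and it too stays within the scatter, so ethyl, isopropyl, oxetan-3-yl and 2,2,2-trifluoroethyl remain unseparated in this assay. No measured property of these groups is available to account for this reading.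

Open is whether a longer chain, an amine-bearing chain or a carboxylic acid on this oxygen would move the number beyond the scatter, a question the four groups shown cannot settle. Also open is whether the same flat reading at this oxygen would hold on cell lines other than the one shown here, or with the other parts of the shared core changed.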